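The source may report more compounds than this note shows. Statements on the series, on what has been measured and on what is new or still open speak of the compounds shown alone.

Compound 1 `CC(C)c1n[nH]c2c(NCc3ccc(-c4ccccn4)cc3)nc(SCCC(N)=O)nc12` is one of three analogues sharing a common core and differing only in the group carried on the sulfur. In a functional assay on HT cells (Homo sapiens) for antiproliferative activity, read by fluorescence, with a stated time of 72 h (a lower number here means a stronger inhibitor of growth, a higher number a weaker inhibitor of growth), compound 1 gives 120 nM, the second highest of the three numbers. Compound 2 `CC(O)CSc1nc(NCc2ccc(-c3ccccn3)cc2)c2[nH]nc(C(C)C)c2n1` gives 62 nM, a change of a 1.9-fold lower number from compound 1 to compound 2 (0.29 log units; within the scatter), while compound 3 `CC(C)c1n[nH]c2c(NCc3ccc(-c4ccccn4)cc3)nc(SC3CCCCC3O)nc12` gives 636 nM, a change of a 5.3-fold higher number from compound 1 to compound 3 (0.72 log units; beyond the scatter); between them lies a 10-fold higher number from compound 2 to compound 3 (1.01 log units; beyond the scatter). Compound 4 `COCSc1nc(NCc2ccc(-c3ccccn3)cc2)c2[nH]nc(C(C)C)c2n1` differs from compound 1 by methoxy in place of carbamoylmethyl on a saturated chain carbon bound to a sulfur. Neither measured step replaces the carbamoylmethyl group by a smaller one, so the data bear on it only loosely. A step in this assay of about a 1.3-fold higher number from compound 1 to compound 4 (0.10 log units; within the scatter) is expected. Compound 4 is therefore estimated at 150 nM, within a range of 60 nM to 400 nM.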

Compound 4, concentration for 50% growth inhibition: 340 nM
Estimate against measurement, compound 4: 2.3-fold (0.36 log units) below; measured number inside the range.
By their numbers in this assay, from the lowest: compounds 2 and 1 (each within the scatter of the next); then compounds 4 and 3 (each within the scatter of the next).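

In this assay, methoxy on the saturated chain carbon bound to a sulfur does not match the two open-chain groups, as the steps of a 2.8-fold higher number from compound 1 to compound 4 (0.45 log units; beyond the scatter) and of a 5.5-fold higher number from compound 2 to compound 4 (0.74 log units; beyond the scatter) show for the carbamoylmethyl and 1-hydroxyethyl groups it replaces. Ring-bearing compound 3 goes against any simple reading by hydroxy content, since the step of a 1.9-fold lower number from compound 3 to compound 4 (0.27 log units; within the scatter) leaves it and compound 4 within the scatter. No measurement shown accounts for these steps. As far as these compounds go, whether a longer methoxy-ending chain, an amine or a carboxylic acid at this place would match compound 2 remains open.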